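Swapping the Fluorophenyl for a Chloro-Nitrophenyl Group

The source may report more compounds than this note shows. Statements on the series, on what has been measured and on what is new or still open speak of the compounds shown alone.

Compound 1 `COc1cc(C2=NN(C(C)=O)C(c3ccc(F)cc3)O2)cc(OC)c1OC` and compound 2 `COc1cc(C2=NN(C(C)=O)C(c3cccc(F)c3)O2)cc(OC)c1OC` share one core and differ only in the fluorophenyl group on a saturated ring carbon. In a functional assay on BGC-823 cells (Homo sapiens) for antiproliferative activity, read by MTT assay, tested at 1 uM (a lower number here means a weaker effect, a higher number a stronger effect of the compound at the concentration tested), compound 1 gives -0.4%, while compound 2 gives 14.7%; the step of a number 15.1 percentage points higher from compound 1 to compound 2 (beyond the scatter) places compound 2 highest of the two measured numbers, though both effects are weak. Compound 3 `COc1cc(C2=NN(C(C)=O)C(c3ccc(Cl)c([N+](=O)[O-])c3)O2)cc(OC)c1OC` carries the change (4-chloro-3-nitrophenyl in place of 3-fluorophenyl on a saturated ring carbon). Among the compounds with values here, the only measured step, the modest a number 15.1 percentage points higher from compound 1 to compound 2 (beyond the scatter), moved a fluorine within the same ring, so it bears only loosely on a replacement that adds a chlorine and a nitro group. There is no measured guide for such a change, so the expected step of a number 0.7 percentage points lower from compound 2 to compound 3 (within the scatter) is small, with no clear direction beyond the scatter. Compound 3 is therefore expected to give about 14%, within a range from -8% to 36%.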

Compound 3, a percentage reported as inhibition, at one concentration (the size of the read-out at that concentration, not a potency): -2.3%
Compound 3: middle estimate off by 16.3 percentage points, on the high side, and the stated range covers the measured number.
By their numbers in this assay, from the lowest: compounds 3 and 1 (each within the scatter of the next); then compound 2.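

In this assay, the 4-chloro-3-nitrophenyl group does not keep the small effect seen with 3-fluorophenyl on this saturated ring carbon (a number 17 percentage points lower from compound 2 to compound 3 (beyond the scatter)). Set against 4-fluorophenyl, the same group cannot be told apart (a number 1.9 percentage points lower from compound 1 to compound 3 (within the scatter)), so among these three groups only the 3-fluorophenyl of compound 2 stands out, and only modestly. Nothing at hand explains why these groups differ in this way.

Still open, going by these compounds, is whether a phenyl ring carrying only the chlorine or only the nitro group would read like compound 2 or like compound 3. Also open, on these data alone, is how a phenyl ring bearing an amine or a carboxylic acid would read at this carbon, and whether any group here can give a clearly stronger effect.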